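Methyl to isopropyl amide on a pyrrolopyrimidinone series toward PLK2

The compounds below may be only part of what the source reports. "The series", "measured", "known", "first", "only" and "open" are said of these compounds alone.

Of the compounds shown here, three sharing a core have been measured in an assay for inhibition of serine/threonine-protein kinase PLK2 (Homo sapiens), read by FRET and Z'-LYTE, with a stated time of 1 h; on this read-out higher numbers stand for weaker inhibition and lower numbers for stronger inhibition. Compound 1 `CCC1C(=O)N(C)c2cnc(-n3ccc4cc(C(=O)NC(C)C)ccc43)nc2N1c1ccn(C)n1` gives 125 nM in this assay, and compound 2 `CCC1C(=O)N(C)c2cnc(-n3ccc4cc(C(=O)NC)ccc43)nc2N1c1ccn(C)n1` gives 218 nM. These two differ only at the amide: isopropyl in place of methyl on an amide-type nitrogen, and the measured step is a 1.7-fold lower number from compound 2 to compound 1 (0.24 log units; within the scatter). Compound 3 `CC[C@@H]1C(=O)N(C)c2cnc(-n3ccc4cc(C(=O)NC)ccc43)nc2N1C1CCCC1` carries a different group on the ring nitrogen of the core; how its core differs from that of compound 2 is not broken down here. In this assay compound 3 gives 8.6 nM, a number lower than those of compound 1 and compound 2 by a margin beyond the scatter.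

Compound 4 `CC[C@@H]1C(=O)N(C)c2cnc(-n3ccc4cc(C(=O)NC(C)C)ccc43)nc2N1C1CCCC1` has not yet been measured. It stands to compound 3 as compound 1 stands to compound 2: isopropyl in place of methyl on an amide-type nitrogen, at the same kind of place, so the change is the same. The expectation for compound 4 rests on the step of a 1.7-fold lower number from compound 2 to compound 1 (0.24 log units; within the scatter), which stayed within the scatter. The expected step is a 1.4-fold lower number from compound 3 to compound 4 (0.16 log units; within the scatter). Compound 4 is therefore estimated to give 6 nM in this assay, with a likely range from 2.5 nM to 14 nM.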

Compound 4, half-maximal inhibitory concentration: 17.4 nM
Beside the measured number, compound 4's estimate is 2.9-fold (0.46 log units) below it; the measured number lies above the stated range.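

In this assay, isopropyl in place of methyl on an amide-type nitrogen gives a 2.0-fold higher number from compound 3 to compound 4 (0.31 log units; beyond the scatter), so on the core of compound 3 the change does not repeat what it did on the core of compound 1. Set side by side, the two steps do not agree, and the change cannot be carried from one of these cores to the other as a fixed step: the same change on two cores in this assay, a 1.7-fold lower number (0.24 log units; within the scatter) from compound 2 to compound 1 and a 2.0-fold higher number (0.31 log units; beyond the scatter) from compound 3 to compound 4, 3.5-fold (0.55 log units) apart, beyond the scatter of two such steps

This rests on a single pair of compounds for each core, and it does not show which difference between the cores separates the two steps, nor how the change would behave on any further core.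

The compounds shown leave open how an ethyl or a cyclopropyl on the same amide nitrogen would read on either core, and so whether the two cores part ways only at isopropyl. Also open, as far as these compounds go, is how a longer chain ending in an amine would read there in this assay.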